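Chloro in Place of Fluoro on Compound 2

The source may report more compounds than this note shows. Statements on the series, on what has been measured and on what is new or still open speak of the compounds shown alone.

Compound 1 `COc1ccc(-c2noc(-c3cc4ccccc4[nH]3)n2)cc1` and compound 2 `COc1ccc(-c2noc(-c3cc4cc(F)ccc4[nH]3)n2)cc1` share one core and differ at a single aromatic carbon. In a functional assay on MIA PaCa-2 cells (Homo sapiens) for antiproliferative activity, read by WST assay, with a stated time of 72 h (on this read-out higher numbers stand for weaker inhibition and lower numbers for stronger inhibition), compound 1 gives only a limit of the assay, > 50000 nM. In this assay compound 2 gives 10300 nM. The step of an at least 4.8-fold lower number from compound 1 to compound 2 (0.68 log units; beyond the scatter) can be bounded but not sized exactly because it rests on (the limit of > 50000 nM in this assay, at which 1 of the 2 values shown sits). Among the numbers shown, compound 2 holds the only measured value; the other entry is a limit.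

Compound 3 `COc1ccc(-c2noc(-c3cc4cc(Cl)ccc4[nH]3)n2)cc1` differs from compound 2 by chloro in place of fluoro on an aromatic carbon. Among the compounds with values here, no measured step exchanges one halogen for another. The only step shown, an at least 4.8-fold lower number from compound 1 to compound 2 (0.68 log units; beyond the scatter), concerns the entry of fluoro at this same carbon and was at least modest toward a lower number, so it bears on the site but not on the exchange itself. The analyst therefore expects a small step for compound 3, more likely toward a lower number, a 2.1-fold lower number from compound 2 to compound 3 (0.31 log units; beyond the scatter). Compound 3 is estimated at 5000 nM in this assay, within 1500 nM to 20000 nM.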

Compound 3, half-maximal inhibitory concentration: 7800 nM
Estimate against measurement, compound 3: 1.6-fold (0.19 log units) below, and the stated range covers the measured number.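

Chloro in place of fluoro at this aromatic carbon gives a 1.3-fold lower number from compound 2 to compound 3 (0.12 log units; within the scatter) in this assay, so on this read-out the two halogens cannot be told apart. The earlier compounds shown here showed a step only for fluoro entering at this carbon, whereas chloro in place of hydrogen now gives an at least 6.4-fold lower number from compound 1 to compound 3 (0.80 log units; beyond the scatter), so the step beyond the scatter seen with one halogen is also seen with a second. Its true size can be bounded but not fixed because compound 1 gives only a limit of the assay: the limit of > 50000 nM in this assay, at which 1 of the 3 values shown sits.

The compounds shown leave open whether this carbon responds only to a halogen or whether a quite different group in the same place, such as an amine, a nitrile or a carboxylic acid, would move the number in either direction, and whether bromo would stay level with fluoro and chloro. They also leave open whether a halogen on another aromatic carbon of the shared core would give a step like these, since every change shown falls on this single carbon.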